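Carboxy removal on the thiophene core: two aryl series

The source may report more compounds than this note shows. Statements on the series, on what has been measured and on what is new or still open speak of the compounds shown alone.

Compound 1 `COc1cc(-c2cc(C(=O)O)sc2-c2ccc3ccccc3c2)cc(OC)c1OC` and compound 2 `COc1cc(-c2ccsc2-c2ccc3ccccc3c2)cc(OC)c1OC` share one core; compound 3 `COc1ccc(-c2cc(C(=O)O)sc2-c2cc(OC)c(OC)c(OC)c2)cc1` and the unmeasured compound 4 `COc1ccc(-c2ccsc2-c2cc(OC)c(OC)c(OC)c2)cc1` share another. How the two cores differ is not broken down here.

In a functional assay on KB cells (Homo sapiens) for antiproliferative activity, read by MTT assay, with a stated time of 72 h (a higher number here means a weaker inhibitor, a lower number a stronger inhibitor), compound 1 gives 5640 nM. In this assay compound 2 gives 3660 nM. The step of a 1.5-fold lower number from compound 1 to compound 2 (0.19 log units; within the scatter) corresponds to the change (hydrogen in place of carboxy on an aromatic carbon).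

In this assay, among the measured compounds shown here, compound 3 gives 8650 nM, the highest of the three numbers so far; against compound 1 the gap lies within the scatter, against compound 2 it lies beyond it.

Compound 4 is obtained from compound 3 by hydrogen in place of carboxy on an aromatic carbon. For the measured compounds named here, this is the same kind of change as the one from compound 1 to compound 2, though the surroundings are not identical: in the first pair the carbon lies two ring bonds from the ring atom that bears a naphthalen-2-yl group, in the second pair two ring bonds from the ring atom that bears a 4-methoxyphenyl group.

Going by the values given here, with only one measured example of this change, the expectation for compound 4 rests on it alone. Among the compounds with values here, the step is expected to be a 1.5-fold lower number from compound 3 to compound 4 (0.17 log units; within the scatter), because the one measured step of a 1.5-fold lower number from compound 1 to compound 2 (0.19 log units; within the scatter) was small and within the scatter. Compound 4 is therefore estimated at 5800 nM in this assay, with a range from 3000 nM to 12000 nM.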

Compound 4, half-maximal inhibitory concentration: 7400 nM
For compound 4 the middle estimate is 1.3-fold (0.11 log units) below the measured one; the range from low to high includes it.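

In this assay, hydrogen in place of carboxy on the core of compound 3 gives a 1.2-fold lower number from compound 3 to compound 4 (0.07 log units; within the scatter), so on this core too the change leaves the number within the scatter. Set beside the earlier step, the change carries from one core to the other with no difference that can be told apart: the same change on two cores in this assay, a 1.5-fold lower number (0.19 log units; within the scatter) from compound 1 to compound 2 and a 1.2-fold lower number (0.07 log units; within the scatter) from compound 3 to compound 4, 1.3-fold (0.12 log units) apart, within the scatter of two such steps This rests on two pairs in a single read-out, so it does not show that the step would stay this small on a further core or in another assay, and it gives no reason for the small size of either step.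

Carboxy and hydrogen are the only two groups shown on the aromatic carbon next to the ring sulfur, which leaves open whether an amide, a methyl ester or an aminomethyl group at that place would move the number beyond the scatter. Also open, from the compounds shown here alone, is whether the same change stays as small on a core that carries neither naphthalen-2-yl nor 4-methoxyphenyl, for instance one with a pyridine ring or a longer alkyl chain in their place.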